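The source may hold more compounds than are shown below. What is called first, only, known or untested is meant among the compounds shown, and "the series" means these compounds.

In a functional assay on MDA-MB-231 cells (Homo sapiens) for antiproliferative activity, read by sulforhodamine B assay, with a stated time of 72 h (on this read-out higher numbers stand for weaker inhibition and lower numbers for stronger inhibition), compound 1 `Fc1ccc(/C=C/c2cc3ccccc3nc2Cl)cc1` gives > 50000 nM, which is a limit of the assay and not a number. Compound 2 `Fc1ccc(/C=C\c2cc3ccc(Cl)cc3nc2Cl)cc1` reads 42600 nM, so both measured compounds lie in the weak range. Compound 3 `COc1ccc2nc(Cl)c(/C=C/c3ccc(F)cc3)cc2c1` differs from compound 1 by methoxy in place of hydrogen on an aromatic carbon. For the measured compounds named here, no measured pair shows this change, so only a modest shift toward stronger inhibition is expected, and the estimated size is an at least 1.6-fold lower number from compound 1 to compound 3 (0.22 log units; that floor lies within the scatter). For compound 3 the expected value is 30000 nM, within an estimated range of 10000 nM to 60000 nM.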

Compound 3, half-maximal inhibitory concentration: 11000 nM
The estimate for compound 3 lay 2.7-fold (0.44 log units) above the measured number; measured number inside the range.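

In this assay, for the compounds shown here, methoxy in place of hydrogen on an aromatic carbon of the shared core gives an at least 4.5-fold lower number from compound 1 to compound 3 (0.65 log units; beyond the scatter), the first change here that can be read as a step and the first sign that this carbon responds to substitution. That step is only a floor, and the real size may be larger, because compound 1 stands at a limit of the assay and not at a number: the limit of > 50000 nM in this assay, at which 1 of the 3 values shown sits.

On these data alone, how a hydroxyl group, an amine or a longer chain such as ethoxy would read at this place stays open. So does the effect of methoxy on another carbon of this ring.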